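From hydroxy to fluoro: compound 3 to compound 4

The source may report more compounds than this note shows. Statements on the series, on what has been measured and on what is new or still open speak of the compounds shown alone.

The series is read in a functional assay on HCT-116 cells (Homo sapiens) for antiproliferative activity, read by MTT assay, with a stated time of 72 h; on this read-out lower numbers stand for stronger inhibition and higher numbers for weaker inhibition. Compound 1 (`C=CC(=O)N1CCC(c2ccccc2)CC1`) gives > 30000 nM, which is a limit of the assay and not a number. For the measured compounds named here, compound 2 (`C=CC(=O)Nc1nc(-c2ccccc2Cl)cs1`) gives 12300 nM, the only actual number so far. Compound 3 (`C=CC(=O)Nc1nc(-c2ccccc2O)cs1`) gives > 30000 nM, which is also a limit of the assay. The position of compound 3 is therefore known from one side only, with the series bounded by the limit of > 30000 nM in this assay, at which 2 of the 3 values shown sit.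

Compound 4 (`C=CC(=O)Nc1nc(-c2ccccc2F)cs1`) carries fluoro in place of hydroxy on an aromatic carbon, ortho to a large group: fluoro in place of hydroxy on an aromatic carbon.

Going by the values given here, the one measured step that bears on this is an at least 2.4-fold higher number from compound 2 to compound 3 (0.38 log units; beyond the scatter). On these data alone, it puts hydroxy in place of chloro on an aromatic carbon and lies beyond the scatter, though its true size stays open. Compound 4 removes that hydroxy, so a move back towards compound 2 is expected, but fluoro is not chloro and the evidence is a single step. The expected change is an at least 1.6-fold lower number from compound 3 to compound 4 (0.22 log units; that floor lies within the scatter), a modest one towards lower numbers. For compound 4 the estimate is 18000 nM, with an expected range of 8000 nM to 30000 nM.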

Compound 4, half-maximal inhibitory concentration: 20400 nM
The estimate for compound 4 lay 1.1-fold (0.05 log units) below the measured number; low and high end bracket the measured number.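

In this assay, for the compounds shown here, fluoro in place of chloro on an aromatic carbon, ortho to a large group, gives a 1.7-fold higher number from compound 2 to compound 4 (0.22 log units; within the scatter), so this change does not separate the two substituents at this position, and chloro is no longer the only group here with an actual number. Fluoro in place of hydroxy gives an at least 1.4-fold lower number from compound 3 to compound 4 (0.16 log units; that floor lies within the scatter), so even this floor does not establish a real gain over hydroxy. Compound 3 gives > 30000 nM, a limit of the assay and not a number, and the true size of the step stays open because of that limit: the limit of > 30000 nM in this assay, at which 2 of the 4 values shown sit.

The compounds shown place only chloro, hydroxy and fluoro at this position, so it remains open whether a methoxy, an amine, a carboxylic acid or a trifluoromethyl there would read like the chloro and fluoro pair or like hydroxy. On these data alone, it is also open whether fluoro and chloro would remain within the scatter of each other in another cell line or at another exposure time.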